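From compound 3 to the amino compound 4

The compounds below may be only part of what the source reports. "The series", "measured", "known", "first", "only" and "open" are said of these compounds alone.

In a functional assay on RKO cells (Homo sapiens) for inhibition, read by MTT assay, with a stated time of 48 h (a higher number here means a weaker inhibitor, a lower number a stronger inhibitor), compound 3 `COc1ccc(N(C)c2nc(C)nc3ccccc23)cc1OCCCC[Se]C#N` gives 1360 nM. Compound 1 `COc1ccc(N(C)c2nc(C)nc3ccccc23)cc1C(=O)OCC[Se]C#N` gives 2390 nM, and the step between them, a 1.8-fold lower number from compound 1 to compound 3 (0.24 log units; within the scatter), lies within the scatter, so the two stand level. Compound 2 `COc1ccc(N(C)c2nc(C)nc3ccccc23)cc1[Se]C`, at 11 nM, is the strongest of the three, since both of its steps are large: a 220-fold lower number from compound 1 to compound 2 (2.34 log units; beyond the scatter) and a 120-fold higher number from compound 2 to compound 3 (2.09 log units; beyond the scatter).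

The next structure is compound 4 `COc1ccc(N(C)c2nc(C)nc3ccccc23)cc1OCCN`, which carries one nitrogen atom in place of a group of 5 heavy atoms (3 carbon, 1 nitrogen, 1 selenium; no ring), on a saturated chain carbon, two bonds along the chain from an oxygen on an aromatic ring. The entering group is an amino group, and the selenium leaves with the rest of the group.

Among the measured compounds shown here, no measured pair isolates this change. For the measured compounds named here, none of the measured compounds has an amino group, and all of them contain selenium. The nearest evidence is indirect: compound 2, with the smallest group of the series, stands apart through a 120-fold higher number from compound 2 to compound 3 (2.09 log units; beyond the scatter), while the two larger groups of compound 1 and compound 3 stay level. The group in compound 4 is smaller than that in compound 3 but differs in kind from that in compound 2, so only part of that large step is expected to carry over.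

The expected step is a 4.5-fold lower number from compound 3 to compound 4 (0.66 log units; beyond the scatter), a modest and uncertain estimate. For compound 4 the estimated value is 300 nM, with an expected range of 40 nM to 2000 nM.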

Compound 4, half-maximal inhibitory concentration: 343 nM
Compound 4: middle estimate off by 1.1-fold (0.06 log units), on the low side; the range from low to high includes it.
By their numbers in this assay, from the lowest: compound 2; then compound 4; then compounds 3 and 1 (each within the scatter of the next).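

In this assay, the amino group in place of the selenium-bearing group, on a saturated chain carbon, two bonds along the chain from an oxygen on an aromatic ring, gives a real gain (a 4.0-fold lower number from compound 3 to compound 4 (0.60 log units; beyond the scatter)), and the gain over the ester-linked compound is of similar modest size (a 7.0-fold lower number from compound 1 to compound 4 (0.84 log units; beyond the scatter)), so selenium is not needed for a compound to stand clear of compound 1 and compound 3. Selenium-free compound 4 still falls well short of the small methylseleno compound (a 31-fold higher number from compound 2 to compound 4 (1.49 log units; beyond the scatter)), so across these four compounds the number rises as the group on the shared core grows, with compound 1 and compound 3 level and none going against this order. No measurement here accounts for any of these steps.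

On these data alone, compound 3 and compound 4 differ in both chain length and end group, so the share of each in the step stays open; an amino group on a four-carbon chain, or a hydroxyl group on the shorter chain, would separate them. As far as these compounds go, whether selenium itself matters in compound 2 also stays open, and a methylthio group in its place would test that.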